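The compounds below may be only part of what the source reports. "The series", "measured", "known", "first", "only" and "open" are said of these compounds alone.

Working notes on the series in a toxicity assay on HT-29 cells (Homo sapiens) for cytotoxicity; on this read-out lower numbers stand for higher toxicity in this test and higher numbers for lower toxicity in this test. Compound 3 (`CN1C(=S)[C@@H](NC(=O)c2nc(Cc3ccccc3)n(C3CCCCCC3)n2)COc2ccccc21`) gives > 100000 nM and this is a limit of the assay, not a number. Compound 1 (`CN1C(=S)[C@@H](NC(=O)c2nc(Cc3ccccc3)n(CCCO)n2)COc2ccccc21`) gives > 100000 nM and this is also a limit. Compound 2 (`CN1C(=S)[C@@H](NC(=O)c2nc(Cc3ccccc3)n(CCCCCC#N)n2)COc2ccccc21`) gives > 100000 nM and this too is a limit. Within the data shown here, the record so far is the limit of > 100000 nM in this assay, at which 3 of the 3 values shown sit, and no compound has a numerical value yet.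

The next change leads to compound 4 (`CN1C(=S)[C@@H](NC(=O)c2nc(Cc3ccccc3)n(C3CCOCC3)n2)COc2ccccc21`) and is described by oxan-4-yl in place of cycloheptyl on an aromatic nitrogen with oxan-4-yl in place of cycloheptyl on an aromatic nitrogen. Among the measured compounds shown here, the steps that bear on it are a step that the two limits leave unreadable from compound 1 to compound 3 and a step that the two limits leave unreadable from compound 2 to compound 3 as changes on that same nitrogen. Neither gives a size, and a step that the two limits leave unreadable from compound 1 to compound 2 gives none either. On that basis the expected step is a number no higher from compound 3 to compound 4 (the limit leaves the size open) with nothing beyond the scatter foreseen in either direction. For compound 4 the estimate is 100000 nM with an expected range from 40000 nM to 200000 nM in this assay and another report as a limit is likely.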

Compound 4, half-maximal cytotoxic concentration: > 100000 nM
Compound 4: only a limit was reported (the forecaster's own chance of this, stated with the estimate: 90%); the middle value sits exactly at the limit.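

In this assay compound 4 gives > 100000 nM, which is a limit of the assay. Among these compounds, no step linking compound 4 to compound 1, compound 2 or compound 3 can be read. The compounds shown leave open how far any group on that aromatic nitrogen shifts the read-out, as all stand at one value: the limit of > 100000 nM in this assay, at which 4 of the 4 values shown sit.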